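Swapping methyl for ethoxy on the aryl group

The source may hold more compounds than are shown below. What is called first, only, known or untested is meant among the compounds shown, and "the series" means these compounds.

Measured in a functional assay on FM3A cells (Mus musculus) for antiproliferative activity; a lower number here means a stronger inhibitor, a higher number a weaker inhibitor:
- Compound 1 `COc1cc(C(=O)c2sc(-c3ccc(Br)cc3)cc2N)cc(OC)c1OC`: 150 nM
- Compound 2 `COc1cc(C(=O)c2sc(-c3ccc(C)cc3)cc2N)cc(OC)c1OC`: 16 nM

Among the measured compounds shown here, with only two compounds measured, compound 2 holds the lower number at 16 nM, which makes it the stronger inhibitor of the pair. The next structure is compound 3 `CCOc1ccc(-c2cc(N)c(C(=O)c3cc(OC)c(OC)c(OC)c3)s2)cc1`, and the change is ethoxy in place of methyl on an aromatic carbon. In words, ethoxy takes the place of methyl on an aromatic carbon, para to a large group, turning 4-methylphenyl into 4-ethoxyphenyl.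

For the measured compounds named here, only one measured step bears on this: a 9.4-fold lower number from compound 1 to compound 2 (0.97 log units; beyond the scatter), where methyl replaced bromo. That step shows that the result in this assay can move clearly when this group changes. Going by the values given here, it does not show how ethoxy will behave, since no measured compound carries that group, and a single step cannot establish a trend. No clear move in either direction is therefore expected, only perhaps a slight weakening. The expected outcome is a 1.3-fold higher number from compound 2 to compound 3 (0.10 log units; within the scatter). For compound 3 the estimated value is 20 nM, with an expected range from 6 nM to 70 nM.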

Compound 3, half-maximal inhibitory concentration: 510 nM
For compound 3 the middle estimate is 26-fold (1.41 log units) below the measured one; measured number above the stated range.
By their numbers in this assay, from the lowest: compound 2; then compound 1; then compound 3.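

Read in this assay, this position proves far less forgiving than the first pair suggested: the swap of methyl for ethoxy gives a 32-fold higher number from compound 2 to compound 3 (1.50 log units; beyond the scatter), a bigger move than a 9.4-fold lower number from compound 1 to compound 2 (0.97 log units; beyond the scatter), and it makes compound 3 the weakest of the three. Ethoxy also falls behind bromo, with a 3.4-fold higher number from compound 1 to compound 3 (0.53 log units; beyond the scatter), so the measured order of the groups on this aromatic carbon runs methyl, then bromo, then ethoxy, and a group that enters with an oxygen and more heavy atoms is not tolerated here as methyl is. No measurement at hand explains why ethoxy costs so much.

With only three groups at this position, the compounds shown cannot tell whether the loss goes with the oxygen attached to the aromatic ring or with the extra length of the chain. Methoxy, which keeps the oxygen on a shorter chain, and ethyl, which keeps the length without the oxygen, would pull those two apart, while chloro would show whether another halogen sits close to bromo.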